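This account rests on a few compounds, and the source may have more. Where it says the series, first, only, none or still open, it means among the compounds named here.

In a functional assay on KB cells (Homo sapiens) for antiproliferative activity, read by sulforhodamine B assay, with a stated time of 3 days (a lower number here means that less compound is needed, a higher number that more compound is needed for the effect), compound 1 (`CCC1=C(O)c2c(oc(-c3ccc(C)cc3)cc2=O)C(CC)(CC)C1=O`) gives 39.2 uM and compound 2 (`CCC1=C(O)c2c(oc(-c3ccc(OC)c(C)c3)cc2=O)C(CC)(CC)C1=O`) gives 28.5 uM on the shared core. Among the compounds with values here, these two values lie within the scatter of each other, so compound 2 stands level with its only measured neighbour. Compound 3 (`CCC1=C(O)c2c(oc(-c3ccc(OC)c(Cl)c3)cc2=O)C(CC)(CC)C1=O`) differs from compound 2 in one group (chloro in place of methyl on an aromatic carbon) with chloro in place of methyl on an aromatic carbon, so 4-methoxy-3-methylphenyl becomes 3-chloro-4-methoxyphenyl. Within the data shown here, the only measured step that bears on this also changes that aromatic ring (a 1.4-fold lower number from compound 1 to compound 2 (0.14 log units; within the scatter)) and it stays within the scatter. Among the measured compounds shown here, no measured pair swaps methyl for chloro, so the data do not show the size of that swap directly, and no step beyond the scatter is expected in this assay here. The expected change is small (a 1.1-fold lower number from compound 2 to compound 3 (0.06 log units; within the scatter)) on this limited evidence. Compound 3 is estimated at 25 uM (expected range 10 uM to 60 uM).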

Compound 3, concentration for half-maximal effect: 24.9 uM
For compound 3 the middle estimate is 1.0-fold (0.00 log units) above the measured one; the measured number falls inside the stated range.
By their numbers in this assay, from the lowest: compounds 3, 2 and 1 (each within the scatter of the next).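

In this assay the swap of chloro for methyl, on an aromatic carbon ortho to a methoxy group, can now be read directly with the methoxy group held fixed: it gives a 1.1-fold lower number from compound 2 to compound 3 (0.06 log units; within the scatter). The wider change of the whole ring, 3-chloro-4-methoxyphenyl in place of 4-methylphenyl, gives a 1.6-fold lower number from compound 1 to compound 3 (0.20 log units; within the scatter), so methyl and chloro cannot be told apart at this position in this assay, and neither ring stands out from the other. No measurement on hand offers an explanation for how alike these numbers are.

As far as these compounds go, it remains open whether a different group at this position, such as an amine, a carboxylic acid or a longer alkyl chain, would move the number beyond the scatter. From the compounds shown here alone, it is also open whether chloro and methyl would still read alike with a hydroxy group in place of the methoxy group.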